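The compounds below may be only part of what the source reports. "The series", "measured", "known", "first", "only" and "open" are said of these compounds alone.

In a toxicity assay on the whole organism with Rattus norvegicus as the target, at a dose of 100 mg/kg by the oral route (a higher number here means a stronger effect of the compound at the dose given, a lower number a weaker effect), the three measured compounds give the following numbers:

Compound 1, `COc1ccc(OCC2=NCCO2)cc1`: 50%
Compound 2, `Brc1ccccc1OCC1=NCCO1`: 70%
Compound 3, `Fc1ccc(OCC2=NCCO2)cc1`: 25%

Compound 2 stands highest of the three; its nearest neighbour on the numbers is compound 1, and the gap to compound 3 is the widest, both gaps lying beyond the scatter. For the measured compounds named here, the only step between compounds that differ in one place is a number 25 percentage points lower from compound 1 to compound 3 (beyond the scatter), which is modest and downward.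

Compound 4, `O=[N+]([O-])c1ccccc1OCC1=NCCO1`, differs from compound 2 by nitro in place of bromo on an aromatic carbon. Going by the values given here, no measured step exchanges bromo for nitro, nor any group at the place ortho to a group of 7 heavy atoms, so the step from compound 1 to compound 3 is only a loose guide: it shows that one substituent exchange on the aromatic carbon moved the number by a modest amount. For compound 4 the account therefore expects a step of similar or smaller size, most likely downward, a number 15 percentage points lower from compound 2 to compound 4 (beyond the scatter). Compound 4 is estimated at 55%, with a range from 30% to 80%.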

Compound 4, a percentage reported as activity, at one dose (the size of the read-out at that dose, not a potency): 30%
Compound 4: the middle estimate sits 25 percentage points above what was measured, and the stated range covers the measured number.
By their numbers in this assay, from the lowest: compounds 3 and 4 (each within the scatter of the next); then compound 1; then compound 2.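

In this assay, nitro in place of bromo on an aromatic carbon, ortho to a group of 7 heavy atoms, gives a number 40 percentage points lower from compound 2 to compound 4 (beyond the scatter). For the compounds shown here, this is the first step read at this place, and it is printed as large, whereas the one earlier step, a number 25 percentage points lower from compound 1 to compound 3 (beyond the scatter), between two other groups, is modest; a single exchange at this place can therefore move the number a long way. Nothing available explains this step.

On these data alone, whether an amine, a chloro group or a methyl group at this place would stand nearer to compound 2 or to compound 4 remains open. Also open, as far as these compounds go, is whether bromo and nitro would keep the same order elsewhere on the aromatic ring, or at a dose other than the single one tested.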